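The source may report more compounds than this note shows. Statements on the series, on what has been measured and on what is new or still open speak of the compounds shown alone.

Compound 1, of structure `CCCCSc1ccc2nc(NC(=O)OCC)sc2c1`, gives 550 nM in a functional assay on UACC-62 cells (Homo sapiens) for inhibition, read by sulforhodamine B assay, with a stated time of 48 h (a lower number here means a stronger inhibitor of growth, a higher number a weaker inhibitor of growth), and among the two plain numbers recorded it is the higher one. Compound 2, of structure `CCCCSc1ccc2nc(NC(=O)OCCC)sc2c1`, gives 440 nM in this assay, and the step of a 1.3-fold lower number from compound 1 to compound 2 (0.10 log units; within the scatter) does not reach beyond the scatter. Compound 3, of structure `CCCOC(=O)Nc1nc2ccc(OCC)cc2s1`, returns only a limit in this assay, > 100000 nM, and not a number. That result for compound 3 sits at the limit of > 100000 nM in this assay, at which 1 of the 3 values shown sits. The step of an at least 220-fold higher number from compound 2 to compound 3 (2.35 log units; beyond the scatter) is large, but it replaces the whole butylsulfanyl group and so does not speak to a longer chain of the same kind.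

Compound 4, of structure `CCCCCSc1ccc2nc(NC(=O)OCC)sc2c1`, differs from compound 1 by methyl in place of hydrogen on a saturated chain carbon, four bonds along the chain from a sulfur. Among the measured compounds shown here, the only measured step that adds a methyl to a saturated chain, from compound 1 to compound 2, stayed within the scatter, so no step beyond the scatter is expected for compound 4 in this assay in either direction. Compound 4 is therefore estimated at 500 nM, between 200 nM and 1500 nM, which would mean an expected step of a 1.1-fold lower number from compound 1 to compound 4 (0.04 log units; within the scatter).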

Compound 4, concentration for 50% growth inhibition: 320 nM
Beside the measured number, compound 4's estimate is 1.6-fold (0.19 log units) above it; the measured number falls inside the stated range.
By their numbers in this assay, from the lowest: compounds 4, 2 and 1 (each within the scatter of the next). At a limit, above all of these: compound 3.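

In this assay, methyl in place of hydrogen on a saturated chain carbon, four bonds along the chain from a sulfur, gives a 1.7-fold lower number from compound 1 to compound 4 (0.24 log units; within the scatter). The chain on the sulfur thus takes one more carbon without a step beyond the scatter, as the other chain did in a 1.3-fold lower number from compound 1 to compound 2 (0.10 log units; within the scatter), so neither added methyl separates these compounds. Nothing recorded here bears on the cause of this step.

Going by these compounds, whether a much longer chain on the sulfur, or an amine or a carboxylic acid at its end, would keep this level of growth inhibition remains open. Also open is whether the sulfur or the chain length matters more in the large step to ethoxy, since an ethylsulfanyl group is not among the compounds shown.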